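Notes on the step from compound 3 to compound 4

The compounds below may be only part of what the source reports. "The series", "measured", "known", "first", "only" and "open" are said of these compounds alone.

In a functional assay on HL60/MX2 cells (Homo sapiens) for antiproliferative activity, read by MTT assay, with a stated time of 48 h (on this read-out higher numbers stand for weaker inhibition and lower numbers for stronger inhibition), compound 1 `Cn1c(N)c(-c2nc3ccccc3[nH]2)c2nc(C#N)c(C#N)nc21` gives > 50000 nM, which is a limit of the assay. Compound 2 `CN(C)CCCn1c(N)c(-c2nc3ccccc3[nH]2)c2nc(C#N)c(C#N)nc21` gives 2390 nM. Compound 3 `CN(C)CCCn1c(N)c(-c2nc3ccccc3o2)c2nc(C#N)c(C#N)nc21` gives 1310 nM, level with compound 2 within the scatter, as a 1.8-fold lower number from compound 2 to compound 3 (0.26 log units; within the scatter) shows. Compound 4 `CN(C)CCCCn1c(N)c(-c2nc3ccccc3o2)c2nc(C#N)c(C#N)nc21` carries (dimethylamino)methyl in place of dimethylamino on a saturated chain carbon, three bonds along the chain from an aromatic nitrogen, that is, 4-(dimethylamino)butyl for 3-(dimethylamino)propyl: (dimethylamino)methyl in place of dimethylamino on a saturated chain carbon, three bonds along the chain from an aromatic nitrogen. Only an at least 20-fold lower number from compound 1 to compound 2 (1.32 log units; beyond the scatter), a large step, touches this chain. For the measured compounds named here, no measured step alters its length, so no step beyond the scatter is expected in this assay. The estimated step is a 1.1-fold higher number from compound 3 to compound 4 (0.06 log units; within the scatter). Compound 4 is expected at 1500 nM, with an estimated range of 600 nM to 4000 nM.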

Compound 4, half-maximal inhibitory concentration: 960 nM
Compound 4: middle estimate off by 1.6-fold (0.19 log units), on the high side; the range from low to high includes it.
By their numbers in this assay, from the lowest: compounds 4, 3 and 2 (each within the scatter of the next, the first and the last beyond it). At a limit, above all of these: compound 1.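

For the compounds shown here, this is the first measured change of chain length at this position: in this assay, 4-(dimethylamino)butyl for 3-(dimethylamino)propyl gives a 1.4-fold lower number from compound 3 to compound 4 (0.14 log units; within the scatter), so the two chains cannot be told apart here. With the dimethylamino end kept, the longer chain therefore holds the level of the shorter one on this core. Nothing at hand gives a cause for this small step.

Still open, on these data alone, is whether 2-(dimethylamino)ethyl or 5-(dimethylamino)pentyl would stay level. Also open, as far as these compounds go, is whether a morpholine or a primary amine at the chain end would do so.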